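The source may hold more compounds than are shown below. What is called first, only, known or untested is meant among the compounds shown, and "the series" means these compounds.

Measured compounds in an ADME assay on CEMx174 cells (Homo sapiens) for cytotoxicity; on this read-out lower numbers stand for higher toxicity in this test and higher numbers for lower toxicity in this test:
compound 1 `CC1=C(C(=O)OCc2ccccc2)C(c2cccc(O)c2)NC(=O)N1` — > 10000 nM
compound 2 `CC1=C(C(=O)OC2CCCCC2)C(c2cccc(O)c2)NC(=O)N1` — > 10000 nM
compound 3 `CCC1=C(C(=O)OCC2CCCCC2)C(c2cccc(N)c2)NC(=O)N1` — > 10000 nM

Every value shown is a limit of this assay and not a number. Compound 1 gives > 10000 nM, a limit. Compound 2 gives > 10000 nM, again a limit. Compound 3 gives > 10000 nM, also a limit. Going by the values given here, the one step between compounds differing in a single place, a step that the two limits leave unreadable from compound 1 to compound 2 (cyclohexyl in place of benzyl on an oxygen next to a carbonyl group), is therefore unreadable in size and direction. Compound 3 stands at the limit of > 10000 nM in this assay, at which 3 of the 3 values shown sit, together with the other two values; nothing separates the three compounds on what is known.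

Compound 4 `CCC1=C(C(=O)OCC2CCCCC2)C(c2ccc(F)cc2)NC(=O)N1` differs from compound 3 by 4-fluorophenyl in place of 3-aminophenyl on a saturated ring carbon. Among the compounds with values here, no measured step touches this place, and the single step on record, a step that the two limits leave unreadable from compound 1 to compound 2, sits at another position and is itself unreadable, so it gives no size for the change. With all three measured compounds at the same limit, the expected step that the limit leaves unreadable from compound 3 to compound 4 is none beyond the scatter, and compound 4 is expected to give 12000 nM, within 5000 nM to 30000 nM, most likely again reported only as a limit.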

Compound 4, half-maximal cytotoxic concentration: > 10000 nM
Compound 4 was reported as a limit (the forecaster's own chance of this, stated with the estimate: 75%); the middle value is on the limit's open side.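

In this assay compound 4 gives > 10000 nM, a limit and not a number. No step can be read from compound 3 to compound 4, since both sit at the same reading: the limit of > 10000 nM in this assay, at which 4 of the 4 values shown sit.

The compounds shown leave open how far any of them lies from that limit, and whether any change on the shared core gives a measurable number.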